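Aryl methyl removal in the shared-core series

The source may hold more compounds than are shown below. What is called first, only, known or untested is meant among the compounds shown, and "the series" means these compounds.

Measured so far:
compound 1 `O=C(CCC(=O)c1cccs1)NCCCO` — 300 mg/kg
compound 2 `Cc1ccc(C23CCC(=O)N2CCCO3)c(C)c1` — a limit of the assay, < 50 mg/kg
compound 3 `O=C1CCC2(c3ccc(Cl)c(Cl)c3)OCCCN12` — a limit of the assay, < 150 mg/kg

In a functional assay on the whole organism (Central nervous system) for activation, with Mus musculus as the target (a lower number here means that less compound is needed, a higher number that more compound is needed for the effect), compound 1 gives 300 mg/kg as a measured number. Compound 2 does not have a number, only (the limit of < 50 mg/kg in this assay, at which 1 of the 3 values shown sits). Compound 3 likewise stands at the limit of < 150 mg/kg in this assay, at which 1 of the 3 values shown sits. Among the compounds with values here, no step between two measured compounds is available, so no measured change of this kind can be drawn on.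

Compound 4 `Cc1ccc(C23CCC(=O)N2CCCO3)cc1` differs from compound 2 by hydrogen in place of methyl on an aromatic carbon. With one carbon removed, the step from compound 2 to compound 4 is expected to stay within the usual scatter, a step that the limit leaves unreadable from compound 2 to compound 4, and a limit may again be reported rather than a number. Compound 4 is estimated at 40 mg/kg, in the range 15 mg/kg to 120 mg/kg.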

Compound 4, dose for half-maximal effect: < 50 mg/kg
Compound 4 was reported as a limit; the forecaster's own chance of this, stated with the estimate: 50%; the middle value is on the limit's open side.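

No step can be read between compound 2 and compound 4, as each is reported only as a limit of the assay. The compounds shown leave open what size of change, if any, hydrogen in place of methyl on an aromatic carbon brings.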